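A chloro moved: compound 3 to compound 4

A few compounds are considered here, and "the series" means these few. Any claim that something is new, unique, unknown or untested is made for them only; others in the source may bear on it.

Measured compounds:
compound 1 `COc1cccc(/C=C/C(=O)c2sc(Nc3ccc(Cl)c(Cl)c3)nc2C)c1`: > 25000 nM
compound 2 `Cc1nc(Nc2cccc(Cl)c2)sc1C(=O)/C=C/c1ccc(Cl)cc1`: > 25000 nM
compound 3 `COc1cccc(/C=C/C(=O)c2sc(Nc3cccc(Cl)c3)nc2C)c1`: > 25000 nM

In a functional assay on Bel-7402 cells (Homo sapiens) for cytotoxicity, read by MTT assay (a higher number here means a weaker inhibitor, a lower number a stronger inhibitor), compound 3 reaches only a limit of the assay, > 25000 nM. Compound 1 likewise gives a limit, > 25000 nM. Compound 2 too stops at a limit, > 25000 nM. All three therefore sit at the limit of > 25000 nM in this assay, at which 3 of the 3 values shown sit, and the two steps that touch compound 3, a step that the two limits leave unreadable from compound 1 to compound 3 and a step that the two limits leave unreadable from compound 2 to compound 3, cannot be read in size or direction because both ends are limits.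

Compound 4 `COc1cccc(/C=C/C(=O)c2sc(Nc3ccc(Cl)cc3)nc2C)c1` differs from compound 3 only by 4-chlorophenyl in place of 3-chlorophenyl on a nitrogen on an aromatic ring. For the measured compounds named here, neither measured step concerns this position, and neither has a readable size, so no measured step bears on the change. With every shown value at the same limit, compound 4 is expected to return a limit as well, a step that the limit leaves unreadable from compound 3 to compound 4 of no readable size. Compound 4 is thus estimated at 30000 nM, within 10000 nM to 100000 nM.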

Compound 4, half-maximal inhibitory concentration: > 25000 nM
Compound 4 ended at the assay's limit; the forecaster's own chance of this, stated with the estimate: 85%; the middle value does not contradict the limit.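

Neither the step from compound 3 to compound 4 nor that from compound 1 to compound 4 can be read in size or direction in this assay, where every compound shown stands only at a limit: the limit of > 25000 nM in this assay, at which 4 of the 4 values shown sit.

The compounds shown leave open whether any change to the shared core gives a readable value in this assay.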